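Swapping an aminopiperidine for a hydroxycyclopentylamine

The source may report more compounds than this note shows. Statements on the series, on what has been measured and on what is new or still open speak of the compounds shown alone.

Compound 1 `COc1cc[nH]c1/C=C1\C(=O)Nc2ccc([N+](=O)[O-])c(N3CC[C@H](O)C3)c21` gives 104 nM in a functional assay on MDA-MB-435 cells (Homo sapiens) for antiproliferative activity, read by MTT assay, with a stated time of 5 days; a higher number here means a weaker inhibitor, a lower number a stronger inhibitor.
Compound 2 `COc1cc[nH]c1/C=C1\C(=O)Nc2ccc([N+](=O)[O-])c(N3CC[C@@H](O)C3)c21` gives 88 nM in this assay.
Compound 3 `COc1cc[nH]c1/C=C1\C(=O)Nc2ccc([N+](=O)[O-])c(N3CCC(N)CC3)c21` gives < 10 nM in this assay.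

Compounds 1 and 2 differ only in the configuration as drawn (the fact that compounds 1 and 2 differ only in the configuration as drawn), and the step of a 1.2-fold lower number from compound 1 to compound 2 (0.07 log units; within the scatter) is within the scatter. For compound 3 the value is a limit of the assay rather than a number (the limit of < 10 nM in this assay, at which 1 of the 3 values shown sits). Compound 3 is the strongest of the three, with an at least 10-fold lower number from compound 1 to compound 3 (1.01 log units; beyond the scatter) and an at least 8.8-fold lower number from compound 2 to compound 3 (0.94 log units; beyond the scatter).

Compound 4 `COc1cc[nH]c1/C=C1\C(=O)Nc2ccc([N+](=O)[O-])c(N[C@H]3CC[C@H](O)C3)c21` carries the change ((3-hydroxycyclopentyl)amino in place of 4-aminopiperidin-1-yl on an aromatic carbon). This brings back a hydroxyl on a five-membered ring, as in compounds 1 and 2, while keeping a nitrogen attached to the aromatic carbon. The steps from compounds 1 and 2 to compound 3 show the amine-bearing piperidine lifting potency sharply; removing it and restoring a hydroxyl is expected to give some of that back, so compound 4 is expected to show an at least 4.0-fold higher number from compound 3 to compound 4 (0.60 log units; beyond the scatter), a weakening in this assay. The estimate for compound 4 in this assay is 40 nM, between 8 nM and 200 nM.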

Compound 4, half-maximal inhibitory concentration: 1000 nM
Compound 4: middle estimate off by 25-fold (1.40 log units), on the low side, and the stated range ends below it.
By their numbers in this assay, from the lowest: compounds 2 and 1 (each within the scatter of the next); then compound 4. At a limit, below all of these: compound 3.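

In this assay, placing (3-hydroxycyclopentyl)amino on this aromatic carbon, ortho to a nitro group, gives an at least 100-fold higher number from compound 3 to compound 4 (2.00 log units; beyond the scatter), and this step rests on a limit rather than a number: the limit of < 10 nM in this assay, at which 1 of the 4 values shown sits.

The new group also falls behind the 3-hydroxypyrrolidin-1-yl compounds, with an 11-fold higher number from compound 2 to compound 4 (1.06 log units; beyond the scatter) and a 9.6-fold higher number from compound 1 to compound 4 (0.98 log units; beyond the scatter), so a hydroxyl on a five-membered ring does not by itself set the level of activity here. Compound 4 is the only one of the four whose ring is carbon only and the only one whose attached nitrogen lies outside its ring, and it is the weakest of them.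

The compounds shown cannot say which of these differences matters most, nor whether the other stereoisomers of compound 4 behave alike. A 4-hydroxypiperidin-1-yl or 3-aminopyrrolidin-1-yl group would help separate the effect of ring size from that of swapping the amine for a hydroxyl.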